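This account rests on a few compounds, and the source may have more. Where it says the series, first, only, none or still open, it means among the compounds named here.

Measured so far:
compound 1, `CC(Oc1ccccc1-c1ccccc1)C1=NCCS1`: < 0.3
compound 2, `CC(Oc1ccccc1-c1ccccc1O)C1=NCCN1`: < 0.3
compound 3, `CC(Nc1ccccc1-c1ccccc1)C1=NCCN1`: 0.5

In a functional assay on CHO cells for agonist activity at Alpha-2B adrenergic receptor (Homo sapiens) (on this read-out higher numbers stand for larger maximal responses and lower numbers for smaller maximal responses), compound 2 gives only a limit, < 0.3, not a number. Compound 1 also sits at a limit there, < 0.3. Compound 3 stands apart with a measured value of 0.5. Most of the picture therefore rests at the floor of what this assay reports: the limit of < 0.3 in this assay, at which 2 of the 3 values shown sit. Compound 4, `Cc1ccccc1-c1ccccc1OC(C)C1=NCCN1`, is not yet measured. It differs from compound 2 in one place: methyl in place of hydroxy on an aromatic carbon. Since compound 2 shows only a limit, the starting point is open; a modest rise in this assay is expected, though another limit would not surprise. For compound 4 the expected value is 0.35, within 0.1 to 0.6, an expected step of a number at least 0.050 higher from compound 2 to compound 4 (that floor lies within the scatter).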

Compound 4, intrinsic activity: the largest response reached, as a fraction of the reference agonist's: < 0.3
Compound 4 was reported as a limit; the forecaster's own chance of this, stated with the estimate: 45%; middle value at least 0.050 away from the limit.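

Compound 2 and compound 4 are both reported only as limits in this assay, and the step between them cannot be read. As far as these compounds go, whether methyl in place of hydroxy changes the maximal response at all remains open.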